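A few compounds are considered here, and "the series" means these few. Any claim that something is new, unique, unknown or untested is made for them only; others in the source may bear on it.

Compounds measured so far:
compound 1, `COc1ccc(C)cc1N1C(=O)CSC1c1cccc(C(=O)NCCCCc2ccccc2)c1`: 300 nM
compound 2, `Cc1ccnc(N2C(=O)CS[C@H]2c2cccc(C(=O)NCCCCn3cccn3)c2)c1`: > 10000 nM

In a functional assay on HOS-TE85 cells (Homo sapiens) for inhibition, read by CCK-8 assay, with a stated time of 72 h (on this read-out higher numbers stand for weaker inhibition and lower numbers for stronger inhibition), compound 1 gives 300 nM. Within the data shown here, this is the only actual number among the two values shown. Compound 2 reaches only a limit of the assay, > 10000 nM, so no number is known for it, and that limit is the limit of > 10000 nM in this assay, at which 1 of the 2 values shown sits. Compound 2 differs from compound 1 in more than one place, so the two values show no more than that one compound gives a number and the other does not.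

Compound 3, `O=C(NCCCCc1ccccc1)c1cccc(C2SCC(=O)N2c2nccs2)c1`, has not yet been measured. It differs from compound 1 in a single place: 1,3-thiazol-2-yl in place of 2-methoxy-5-methylphenyl on an amide-type nitrogen in a ring. The group that leaves is a six-membered aromatic ring of carbon only with one hydrogen-bond acceptor; the group that enters is a five-membered aromatic ring with two hetero atoms and two hydrogen-bond acceptors. Among the measured compounds shown here, no measured pair tracks a change of this kind, so the size of the step is open. The expectation is that the step from compound 1 to compound 3 in this assay runs towards weaker inhibition, by a 6.7-fold higher number from compound 1 to compound 3 (0.82 log units; beyond the scatter), a step beyond the usual scatter. Compound 3 is therefore expected to give about 2000 nM, within a range from 400 nM to 10000 nM.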

Compound 3, half-maximal inhibitory concentration: > 1000 nM
Compound 3 was reported as a limit; the forecaster's own chance of this, stated with the estimate: 30%; the middle value is on the limit's open side.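

In this assay the change from 2-methoxy-5-methylphenyl to 1,3-thiazol-2-yl on the amide-type nitrogen in a ring gives an at least 3.3-fold higher number from compound 1 to compound 3 (0.52 log units; beyond the scatter) and is the only comparison shown in which just one place differs. It shows that the group at this position matters, since this replacement loses inhibition by more than the usual scatter while the rest of the molecule stays the same. Compound 3 gives only a limit of the assay, so this step has a known lower bound but no known size: the limit of > 1000 nM in this assay, at which 1 of the 3 values shown sits.

The single replacement cannot separate the roles of ring size, the hetero atoms in the ring and the methoxy and methyl groups that leave with the phenyl ring, and no cause for the loss can be given. A phenyl ring carrying only a methoxy group, an unsubstituted phenyl ring or a cyclohexyl ring at this position would show which of these features the value of compound 1 depends on, and whether any replacement can match or improve on it.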